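A benzyl for phenyl swap on a weak compound

A few compounds are considered here, and "the series" means these few. Any claim that something is new, unique, unknown or untested is made for them only; others in the source may bear on it.

In a functional assay on THP-1 cells (Homo sapiens) for inhibition, read by ELISA, with stated times of 2 h and 48 h (on this read-out higher numbers stand for weaker inhibition and lower numbers for stronger inhibition), compound 1 (`[O-]/[N+](=C\c1cn(-c2ccc(F)cc2)nn1)c1ccccc1`) gives > 20000 nM as a limit of the assay and not a number. Compound 2 (`[O-]/[N+](=C\c1cn(-c2ccc(Cl)cc2)nn1)c1ccccc1`) gives > 20000 nM as a limit too. Compound 3 (`CCCCCCCCCCn1cc(/C=[N+](\[O-])c2ccccc2)nn1`) gives 9900 nM as an actual number.

Compound 4 (`[O-]/[N+](=C\c1cn(-c2ccc(F)cc2)nn1)Cc1ccccc1`) awaits measurement. It carries benzyl in place of phenyl on a double-bonded nitrogen in the core of compound 1 (benzyl in place of phenyl on a double-bonded nitrogen). Among the compounds with values here, the only measured step is chloro in place of fluoro on an aromatic carbon (a step that the two limits leave unreadable from compound 1 to compound 2), which has no readable size and leaves that nitrogen untouched. Within the data shown here, no measured compound carries benzyl there, so no size can be carried over. No step beyond the scatter is therefore expected in this assay in either direction. The expected change is a number no higher from compound 1 to compound 4 (the limit leaves the size open) and no more than that. Compound 4 is estimated at 20000 nM with an expected range from 9000 nM to 40000 nM on this read-out.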

Compound 4, half-maximal inhibitory concentration: 9700 nM
Estimate against measurement, compound 4: 2.1-fold (0.31 log units) above; the range from low to high includes it.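

In this assay, within the data shown here, benzyl in place of phenyl on a double-bonded nitrogen gives an at least 2.0-fold lower number from compound 1 to compound 4 (0.31 log units; beyond the scatter), the first step in this set with a readable direction. The group on this nitrogen, whose other neighbours are carbon with a double bond to nitrogen and oxygen, therefore influences the read-out, whereas the change of chloro for fluoro on an aromatic carbon gave a step that cannot be read. The step's full size stays unknown, because compound 1 carries a limit of the assay and not a number: the limit of > 20000 nM in this assay, at which 2 of the 4 values shown sit.

The compounds shown leave open whether phenethyl in place of benzyl on that nitrogen would lower the number further, and whether a benzyl carrying an amine or a carboxylic acid would keep the step. They also leave open whether benzyl gives a similar step on the core of compound 2, which carries chloro in place of fluoro.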